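Swapping the acid-bearing ring on the cyclopropane linker

The source may report more compounds than this note shows. Statements on the series, on what has been measured and on what is new or still open speak of the compounds shown alone.

Of the compounds shown here, three that share one core have been measured in an assay on HEK293 cells for agonist activity at Bile acid receptor (Homo sapiens); on this read-out lower numbers stand for an effect already at smaller amounts and higher numbers for an effect only at larger amounts of compound. Compound 1 `O=C(O)c1cncc(C2CC2c2ccc(OCc3c(-c4c(Cl)cccc4Cl)noc3C3CC3)cc2Cl)c1` gives 14 nM in this assay. Compound 2 `CO[C@]1(c2ccc(OCc3c(-c4c(Cl)cccc4Cl)noc3C3CC3)cc2Cl)C[C@H](c2cccc(C(=O)O)c2)C1` gives 102 nM. Compound 3 `CC(C)n1nc(C(=O)O)cc1[C@@H]1C[C@H]1c1ccc(OCc2c(-c3c(Cl)cccc3Cl)noc2C2CC2)cc1Cl` gives 4 nM, the lowest of the three numbers; its distance to compound 1 and its larger distance to compound 2 both lie beyond the usual scatter, so compound 3 is the most potent of the measured set.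

Compound 4 `O=C(O)c1cccc([C@@H]2C[C@H]2c2ccc(OCc3c(-c4c(Cl)cccc4Cl)noc3C3CC3)cc2Cl)c1` has not yet been measured. It differs from compound 3 in one place: 3-carboxyphenyl in place of 3-carboxy-1-isopropyl-1H-pyrazol-5-yl on a saturated ring carbon. The same 3-carboxyphenyl group is present in compound 2, though on a different part of the molecule, and compound 1 also carries an acid on a six-membered aromatic ring at the place in question. Those two compounds sit above compound 3 in this assay, which suggests that replacing the pyrazole acid with a benzoic acid is likely to cost some potency.

The step from compound 3 to compound 4 is therefore expected to be a 3.8-fold higher number from compound 3 to compound 4 (0.57 log units; beyond the scatter), a shift toward higher numbers beyond the scatter. Compound 4 is estimated to give about 15 nM in this assay, with a likely range from 5 nM to 45 nM.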

Compound 4, half-maximal effective concentration: 29 nM
Beside the measured number, compound 4's estimate is 1.9-fold (0.29 log units) below it; low and high end bracket the measured number.
By their numbers in this assay, from the lowest: compound 3; then compound 1; then compound 4; then compound 2.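

The direct exchange at this saturated ring carbon shows that, in this assay, the ring carrying the acid matters even though both groups keep a carboxylic acid: 3-carboxyphenyl in place of 3-carboxy-1-isopropyl-1H-pyrazol-5-yl gives a 7.3-fold higher number from compound 3 to compound 4 (0.86 log units; beyond the scatter). The comparison with the pyridine acid adds a second, smaller change, with 2-(3-carboxyphenyl)cyclopropyl in place of 2-(5-carboxypyridin-3-yl)cyclopropyl giving a 2.1-fold higher number from compound 1 to compound 4 (0.32 log units; beyond the scatter), so even between two six-membered aromatic rings the choice of ring registers in this read-out. Nothing shown here explains either shift.

The pyrazole group differs from 3-carboxyphenyl in both its ring and its isopropyl group, so it remains open which of these accounts for the lower number of compound 3, a question that a pyrazole acid carrying a methyl group instead of isopropyl could help to separate. Compound 1 is also drawn without the defined stereochemistry of compound 4 on the cyclopropane, which leaves open how much of their gap belongs to the ring exchange alone.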